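Benzyl for 2-bromophenyl on the amine of compound 2

A few compounds are considered here, and "the series" means these few. Any claim that something is new, unique, unknown or untested is made for them only; others in the source may bear on it.

For the measured compounds named here, compound 2 `O=C(C1=C(Nc2ccccc2Br)C(=O)N(CCCn2ccnc2)C1c1ccc(Br)cc1)c1ccccc1` gives 20100 nM in a functional assay on A549 cells (Homo sapiens) for antiproliferative activity, read by MTT assay, with a stated time of 72 h (on this read-out lower numbers stand for stronger inhibition and higher numbers for weaker inhibition), the highest of the two numbers so far. Its nearest neighbour is compound 1 `CCCCCOC1=C(C(=O)c2ccccc2)C(c2ccc(Br)cc2)N(CCCn2ccnc2)C1=O`, which in this assay gives 7290 nM; the step of a 2.8-fold higher number from compound 1 to compound 2 (0.44 log units; beyond the scatter) came with (2-bromophenyl)amino in place of pentyloxy on a double-bonded ring carbon of the shared core.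

Compound 3 `O=C(C1=C(NCc2ccccc2)C(=O)N(CCCn2ccnc2)C1c1ccc(Br)cc1)c1ccccc1` differs from compound 2 in one place: benzyl in place of 2-bromophenyl on an amine nitrogen. Going by the values given here, no measured step touches the group on this amine nitrogen, since the only step available swaps the whole substituent on the ring carbon rather than the group on the nitrogen. Among the compounds with values here, the single step on record, from compound 1 to compound 2, was modest, which suggests that changes at this position move this assay only modestly; no direction can be read from it for the present change.

Compound 3 is therefore expected to sit close to compound 2, with a step of a 1.3-fold lower number from compound 2 to compound 3 (0.13 log units; within the scatter) that need not exceed the scatter. The estimate for compound 3 in this assay is 15000 nM, with a range from 5000 nM to 45000 nM.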

Compound 3, half-maximal inhibitory concentration: 52800 nM
Compound 3: middle estimate off by 3.5-fold (0.55 log units), on the low side; measured number above the stated range.
By their numbers in this assay, from the lowest: compound 1; then compound 2; then compound 3.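

In this assay the group on the amine nitrogen turns out to matter, with a 2.6-fold higher number from compound 2 to compound 3 (0.42 log units; beyond the scatter) when benzyl replaces 2-bromophenyl, even though the two groups match in heavy-atom count, in their single six-membered aromatic ring and in their donor and acceptor counts. Measured against the pentyloxy compound, the benzylamino compound shows a 7.2-fold higher number from compound 1 to compound 3 (0.86 log units; beyond the scatter) and so lies further from compound 1 than the (2-bromophenyl)amino compound does, which makes pentyloxy the group with the lowest number of the three on the double-bonded ring carbon, with no exception among compounds 1, 2 and 3. No measured information on record accounts for either step.

The compounds shown do not separate the bromine from the carbon inserted between the amine nitrogen and the ring, so a plain phenylamino group or a longer chain such as phenethylamino would be needed to tell these apart. Also open, from the compounds shown here alone, is whether the oxygen link or the pentyl chain sets compound 1 apart, a question that a pentylamino group on the same ring carbon would address directly.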